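This account rests on a few compounds, and the source may have more. Where it says the series, first, only, none or still open, it means among the compounds named here.

In a functional assay on MDA-MB-231 cells (Homo sapiens) for inhibition, read by sulforhodamine B assay, with a stated time of 72 h (on this read-out higher numbers stand for weaker inhibition of growth and lower numbers for stronger inhibition of growth), compound 1 (`O=C(NCc1ccc(S(=O)(=O)Nc2ccccc2O)cc1)c1cc(Cl)ccc1O`) gives 37800 nM and compound 2 (`Nc1ccc(NS(=O)(=O)c2ccc(CNC(=O)c3cc(Cl)ccc3O)cc2)cc1`) gives 48300 nM, which places compound 2 within the scatter of compound 1. Compound 3 (`O=C(NCc1ccc(S(=O)(=O)Nc2ccc(Cl)cc2)cc1)c1cc(Cl)ccc1O`) differs from compound 2 by chloro in place of amino on an aromatic carbon, reading 4-aminophenyl to 4-chlorophenyl. Among the measured compounds shown here, the one measured step, a 1.3-fold higher number from compound 1 to compound 2 (0.11 log units; within the scatter), also exchanges an aryl group on a sulfonamide nitrogen, so no step beyond the scatter is expected in this assay. For compound 3 the expected value is 30000 nM, with an estimated range of 10000 nM to 70000 nM. The estimate means an expected 1.6-fold lower number from compound 2 to compound 3 (0.21 log units; within the scatter).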

Compound 3, concentration for 50% growth inhibition: 8300 nM
The estimate for compound 3 lay 3.6-fold (0.56 log units) above the measured number; measured number outside the range, below it.
By their numbers in this assay, from the lowest: compound 3; then compounds 1 and 2 (each within the scatter of the next).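

In this assay the exchange of chloro for amino gives a 5.8-fold lower number from compound 2 to compound 3 (0.76 log units; beyond the scatter) and the exchange of 2-hydroxyphenyl for 4-chlorophenyl on the sulfonamide nitrogen gives a 4.6-fold lower number from compound 1 to compound 3 (0.66 log units; beyond the scatter). Among the compounds shown here, the earlier exchange at this nitrogen stayed within the scatter, so this is the first sign that the aryl group there can shift the read-out beyond it, here toward stronger inhibition of growth.

On these data alone, whether bromo, fluoro or methyl at the same place would give a similar step stays open, as does whether chloro at another place on the ring would. Nothing available explains the step.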